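Swapping Fluoro for Chloro on the Fused Ring

This account rests on a few compounds, and the source may have more. Where it says the series, first, only, none or still open, it means among the compounds named here.

Of the compounds shown here, two have been measured so far, compound 1 `COc1ccc(CN2C(=O)C(=O)c3cccc(Cl)c32)cc1` and compound 2 `O=C1C(=O)N(Cc2ccc(C(F)(F)F)cc2)c2c(F)cccc21`. In a functional assay on CHO cells for positive allosteric modulation of muscarinic acetylcholine receptor M5 (Homo sapiens), read by calcium flux (on this read-out higher numbers stand for an effect only at larger amounts of compound and lower numbers for an effect already at smaller amounts), compound 1 gives 3960 nM, and in this assay compound 2 gives 3260 nM. The two numbers lie close together, and the gap between them falls within the usual scatter of repeated measurements, so neither compound can be said to act at a smaller amount than the other.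

Compound 3 `O=C1C(=O)N(Cc2ccc(C(F)(F)F)cc2)c2c(Cl)cccc21` has not yet been measured. It differs from compound 2 in one place only: chloro in place of fluoro on an aromatic carbon. Going by the values given here, no measured pair differs in exactly this way, so there is no direct step to lean on. The expected step from compound 2 to compound 3, a 1.1-fold lower number from compound 2 to compound 3 (0.04 log units; within the scatter), is estimated to be no larger than the scatter, in either direction. The estimate for compound 3 in this assay is 3000 nM, with a range from 1200 nM to 8000 nM.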

Compound 3, half-maximal effective concentration: 2110 nM
The estimate for compound 3 lay 1.4-fold (0.15 log units) above the measured number; low and high end bracket the measured number.
By their numbers in this assay, from the lowest: compounds 3, 2 and 1 (each within the scatter of the next).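

In this assay, going by these compounds alone, chloro in place of fluoro on this aromatic carbon, ortho to a fused ring, gives a 1.5-fold lower number from compound 2 to compound 3 (0.19 log units; within the scatter), so the first direct reading of this change shows that the swap does not move the number beyond the scatter. Trifluoromethyl in place of methoxy on an aromatic carbon, with chloro held in place on the shared core, gives a 1.9-fold lower number from compound 1 to compound 3 (0.27 log units; within the scatter), so this second change also stays within the scatter. No measurement at hand accounts for the size of either step.

On these data alone, whether a plain hydrogen, a nitrile or an amine on the same aromatic carbon would produce a step beyond the scatter remains open. The same question stands for a carboxylic acid in the place held by trifluoromethyl or methoxy.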